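Adding a hydroxyethyl arm on compound 1

A few compounds are considered here, and "the series" means these few. Any claim that something is new, unique, unknown or untested is made for them only; others in the source may bear on it.

Compound 1, with the structure `Cn1c(Cc2nn(C)c(=O)c3ccccc23)nnc1SCC(=O)Nc1ccc(Cl)cc1Cl`, is the starting point. In an assay on 32D cells for inhibition of interleukin-15 (Mus musculus), read by resazurin assay, with stated times of 30 min and 2.5 days, in the presence of a further agent that is not named here (on this read-out higher numbers stand for weaker inhibition and lower numbers for stronger inhibition), compound 1 gives 22500 nM, the higher of the two numbers measured. The other measured compound, compound 2, with the structure `CCOC(CCn1c(Cc2nn(C)c(=O)c3ccccc23)nnc1SCCCCCCCC(=O)Nc1ccc(Cl)cc1Cl)OCC`, gives 12100 nM in this assay, and the gap between these two values lies within the ordinary scatter, so neither can be called the stronger inhibitor.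

Compound 3, with the structure `Cn1nc(Cc2nnc(SCC(=O)Nc3ccc(Cl)cc3Cl)n2CCCO)c2ccccc2c1=O`, has not yet been measured. It differs from compound 1 in one place: 2-hydroxyethyl in place of hydrogen on a saturated chain carbon bound to an aromatic nitrogen. Going by the values given here, no measured pair shows this particular change, so there is no step to lean on. A small group added at this position is expected to move the number little, and the step from compound 1 to compound 3 is expected to be a 1.3-fold lower number from compound 1 to compound 3 (0.10 log units; within the scatter), not clearly beyond the scatter. For compound 3 the estimate in this assay is 18000 nM, within a range from 6000 nM to 50000 nM.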

Compound 3, half-maximal inhibitory concentration: > 30000 nM
Compound 3 was reported as a limit; the forecaster's own chance of this, stated with the estimate: 15%; middle value at least 1.6-fold (0.22 log units) away from the limit.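

Compound 3 gives > 30000 nM in this assay, and this is a limit of the assay, not a number. Going by these compounds alone, this is the first single change at this position, and the step reads as an at least 1.3-fold higher number from compound 1 to compound 3 (0.12 log units; that floor lies within the scatter), so 2-hydroxyethyl in place of hydrogen shows no sign of stronger inhibition, while the floor of the step alone does not establish weaker inhibition. The true size of the step stays unknown, as the reading stops at a limit: the limit of > 30000 nM in this assay, at which 1 of the 3 values shown sits.

Going by these compounds, it remains open whether an amine or a carboxylic acid at the end of this chain, in place of the hydroxyl of the 3-hydroxypropyl group, would read differently, or whether a plain ethyl group would. Compound 2 differs from compound 1 in more than one place, so it cannot settle what this position alone allows.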